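Aryl amide swap on the pyrrole carboxamide series

The source may report more compounds than this note shows. Statements on the series, on what has been measured and on what is new or still open speak of the compounds shown alone.

Compound 3 `CCn1c(C(=O)Nc2cccc(C(F)(F)F)c2)ccc1C(CC)(CC)c1ccc(OCC(=O)C(C)(C)C)c(C)c1` stands at the top of what was measured: in an assay on HL-60 cells for agonist activity at vitamin D3 receptor (Homo sapiens), read by microscopy, with a stated time of 96 h (on this read-out lower numbers stand for an effect already at smaller amounts and higher numbers for an effect only at larger amounts of compound), compound 3 gives only a limit, > 50000 nM. Compound 1 `CC[C@@H](C)[C@H](NC(=O)c1ccc(C(CC)(CC)c2ccc(OCC(=O)C(C)(C)C)c(C)c2)n1CC)C(=O)OC` gives 590 nM in this assay, and compound 2 `CCn1c(C(=O)N(CCC#N)CCC#N)ccc1C(CC)(CC)c1ccc(OCC(=O)C(C)(C)C)c(C)c1` gives 870 nM; the step of a 1.5-fold higher number from compound 1 to compound 2 (0.17 log units; within the scatter) is within the scatter. From the compounds shown here alone, the two steps to compound 3, an at least 84-fold higher number from compound 1 to compound 3 (1.92 log units; beyond the scatter) and an at least 57-fold higher number from compound 2 to compound 3 (1.75 log units; beyond the scatter), are both large, and both rest on (the limit of > 50000 nM in this assay, at which 1 of the 3 values shown sits), so their true size is unknown.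

Compound 4 `CCOc1ccc(NC(=O)c2ccc(C(CC)(CC)c3ccc(OCC(=O)C(C)(C)C)c(C)c3)n2CC)cc1` differs from compound 3 in one place: 4-ethoxyphenyl in place of 3-(trifluoromethyl)phenyl on an amide-type nitrogen. Going by the values given here, no measured step compares one aryl group with another on this amide nitrogen, so the measured steps bear on it only indirectly: compound 3 carries an aryl amide and sits at the limit, whereas compound 1 and compound 2 carry non-aromatic groups and give numbers. Compound 4 keeps an aryl amide, and the step of an at least 1.2-fold lower number from compound 3 to compound 4 (0.09 log units; that floor lies within the scatter) is therefore expected to be small or none. Compound 4 is estimated at 40000 nM, with a range from 5000 nM to 200000 nM.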

Compound 4, half-maximal effective concentration: > 50000 nM
Compound 4 gave a limit, no number (the forecaster's own chance of this, stated with the estimate: 55%); middle value at least 1.2-fold (0.09 log units) from the limit.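

In this assay, a second aryl group on the amide-type nitrogen, 4-ethoxyphenyl, also ends at a limit of the assay, so this outcome no longer rests on 3-(trifluoromethyl)phenyl alone: the limit of > 50000 nM in this assay, at which 2 of the 4 values shown sit.

Set against the amides with non-aromatic groups, the change gives two large steps, an at least 57-fold higher number from compound 2 to compound 4 (1.75 log units; beyond the scatter) and an at least 84-fold higher number from compound 1 to compound 4 (1.92 log units; beyond the scatter). Both aryl amides stand only as limits, so the step from one to the other cannot be read and the two aryl groups cannot be ranked.

From the compounds shown here alone, it remains open whether a benzyl group or a pyridyl ring on this amide-type nitrogen would give a measurable number. Also open, going by these compounds, is how far beyond the limit the true values of the two aryl amides lie.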